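The compounds below may be only part of what the source reports. "The series", "measured", "known", "first", "only" and "open" are said of these compounds alone.

Of the compounds shown here, two share a core and have been measured in an assay on isolated protein for inhibition of Ca2+/calmodulin-dependent protein kinase II (CaM kinase II) (Rattus norvegicus), tested at 30 uM; on this read-out higher numbers stand for more inhibition at the one concentration tested (going by the name of the read-out) and lower numbers for less inhibition. Compound 1 `Cn1c(-c2ccccc2)nc2c(Sc3ccccc3)ncnc21` gives 1% in this assay, and compound 2 `Cn1c(Br)nc2c(Sc3ccccc3)ncnc21` gives 0%; the step of a number 1 percentage points lower from compound 1 to compound 2 (within the scatter) is within the scatter, so neither number can be called the higher one. Compound 2 thus stands lowest of the two numbers only nominally, its nearest neighbour compound 1 being within the scatter.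

Compound 3 `Cn1c(C#CCCO)nc2c(Sc3ccccc3)ncnc21` differs from compound 2 by 4-hydroxybut-1-yn-1-yl in place of bromo on an aromatic carbon. Among the compounds with values here, the only measured step at this position, the exchange of phenyl for bromo, was a number 1 percentage points lower from compound 1 to compound 2 (within the scatter) and within the scatter; both measured compounds show almost no inhibition. Within the data shown here, nothing among the measured compounds therefore points to a step beyond the scatter, and the expected step is a number 3 percentage points higher from compound 2 to compound 3 (within the scatter). Compound 3 is estimated to give 3% in this assay, in a range from 0% to 20%.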

Compound 3, a percentage reported as inhibition, at one concentration (the size of the read-out at that concentration, not a potency): 10%
Compound 3: middle estimate off by 7 percentage points, on the low side; the measured number falls inside the stated range.
By their numbers in this assay, from the lowest: compounds 2, 1 and 3 (each within the scatter of the next).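

Putting 4-hydroxybut-1-yn-1-yl in place of bromo on this aromatic carbon gives, in this assay, a number 10 percentage points higher from compound 2 to compound 3 (within the scatter), and putting it in place of phenyl gives a number 9 percentage points higher from compound 1 to compound 3 (within the scatter) as well. So a chain with a triple bond, one hydrogen-bond donor and one hydrogen-bond acceptor, none of which bromo brings, still gives no step beyond the scatter, and the three groups at this position cannot be told apart in this assay. Nothing at hand explains this outcome.

From the compounds shown here alone, whether a group at this position can give a step beyond the scatter at all remains open, for instance a chain ending in an amine or a carboxylic acid, or a longer chain. Going by these compounds, it is also open whether the triple bond and the hydroxy group of compound 3 each count for anything on their own.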